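The compounds below may be only part of what the source reports. "The series", "measured", "known", "first", "only" and "open" are said of these compounds alone.

In a functional assay on NCI-H1975 cells (Homo sapiens) for antiproliferative activity (a higher number here means a weaker inhibitor, a lower number a stronger inhibitor), compound 1 (`Cc1c2c(n3c1CCN(C(=O)C1(N)CC1)C[C@@H](C)[C@H](C)Nc1cc-3ccc1C(N)=O)CC(C)(C)CC2=O`) gives 72 nM and compound 2 (`Cc1c2c(n3c1CCN(C(=O)[C@H](C)O)C[C@@H](C)[C@H](C)Nc1cc-3ccc1C(N)=O)CC(C)(C)CC2=O`) gives 52 nM, so compound 2 stands level with compound 1 within the scatter. Compound 3 (`Cc1c2c(n3c1CCN(C(=O)[C@@H](O)C(C)C)C[C@@H](C)[C@H](C)Nc1cc-3ccc1C(N)=O)CC(C)(C)CC2=O`) differs from compound 2 by isopropyl in place of methyl on a saturated chain carbon bound to a carbonyl carbon and an oxygen on a saturated carbon, which turns 1-hydroxyethyl into 1-hydroxy-2-methylpropyl. Among the measured compounds shown here, the one measured step, a 1.4-fold lower number from compound 1 to compound 2 (0.14 log units; within the scatter), stayed within the scatter, but it changed a different feature, and no measured step tests this enlargement. No shift beyond the scatter is therefore expected in this assay. The estimated step is a 1.2-fold higher number from compound 2 to compound 3 (0.06 log units; within the scatter). The value expected for compound 3 is 60 nM, with an estimated range of 25 nM to 150 nM.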

Compound 3, half-maximal inhibitory concentration: 31 nM
The estimate for compound 3 lay 1.9-fold (0.29 log units) above the measured number, and the stated range covers the measured number.
By their numbers in this assay, from the lowest: compounds 3, 2 and 1 (each within the scatter of the next, the first and the last beyond it).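

In this assay the enlargement of methyl to isopropyl on this saturated chain carbon gives a 1.7-fold lower number from compound 2 to compound 3 (0.22 log units; within the scatter) so this position accepts the larger group with no shift beyond the scatter. With 1-hydroxy-2-methylpropyl in place of 1-aminocyclopropyl on a carbonyl carbon, the series shows a 2.3-fold lower number from compound 1 to compound 3 (0.37 log units; beyond the scatter) and this modest step is the first shown here to pass beyond the scatter. No measurement available here accounts for either step.

On these data alone, whether a longer chain or a cyclohexyl group on this carbon would hold the number stays open. So does the outcome of an amine in place of the oxygen on this saturated carbon.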